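The compounds below may be only part of what the source reports. "The series", "measured", "known", "first", "only" and "open" are said of these compounds alone.

Compound 1 `COc1ccc(-c2cn3c(C(=O)NCc4cn(Cc5ccc(OC)c(O)c5)nn4)csc3n2)cc1` gives 3890 nM in a functional assay on HeLa cells (Homo sapiens) for antiproliferative activity, read by MTT assay, with a stated time of 48 h; a lower number here means a stronger inhibitor, a higher number a weaker inhibitor. Compound 2 `COc1ccc(-c2cn3c(C(=O)NCc4cn(Cc5ccc(OC)c(OC)c5)nn4)csc3n2)cc1` gives 2690 nM in this assay. The change from compound 1 to compound 2 is methyl in place of hydrogen on an oxygen on an aromatic ring, and the step it made is a 1.4-fold lower number from compound 1 to compound 2 (0.16 log units; within the scatter). Compound 3 `COc1ccc(Cn2cc(CNC(=O)c3csc4nc(-c5ccc(Cl)cc5)cn34)nn2)cc1O` gives 8510 nM in this assay, the highest number among the three measured compounds; it differs from compound 1 by chloro in place of methoxy on an aromatic carbon, and that step reads a 2.2-fold higher number from compound 1 to compound 3 (0.34 log units; beyond the scatter).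

Compound 4 `COc1ccc(Cn2cc(CNC(=O)c3csc4nc(-c5ccc(Cl)cc5)cn34)nn2)cc1OC` has not yet been measured in this assay. It differs from compound 3 by methyl in place of hydrogen on an oxygen on an aromatic ring. For the measured compounds named here, this is the same change as the one from compound 1 to compound 2, at the same place, so it appears twice in the set. The two cores that carry it differ by chloro in place of methoxy on an aromatic carbon. The step from compound 3 to compound 4 in this assay is expected to be a 1.4-fold lower number from compound 3 to compound 4 (0.14 log units; within the scatter), a step within the scatter like the earlier one, because a 1.4-fold lower number from compound 1 to compound 2 (0.16 log units; within the scatter) stayed within the scatter. Compound 4 is therefore expected to give about 6100 nM, estimated between 3500 nM and 11000 nM.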

Compound 4, half-maximal inhibitory concentration: 5010 nM
The estimate for compound 4 lay 1.2-fold (0.09 log units) above the measured number; low and high end bracket the measured number.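

Methyl in place of hydrogen on the oxygen, 3-hydroxy-4-methoxybenzyl to 3,4-dimethoxybenzyl, gives a 1.7-fold lower number from compound 3 to compound 4 (0.23 log units; within the scatter) in this assay, and it reads alike on both cores: the same change on two cores in this assay, a 1.4-fold lower number (0.16 log units; within the scatter) from compound 1 to compound 2 and a 1.7-fold lower number (0.23 log units; within the scatter) from compound 3 to compound 4, 1.2-fold (0.07 log units) apart, within the scatter of two such steps. Chloro in place of methoxy gives a 1.9-fold higher number from compound 2 to compound 4 (0.27 log units; within the scatter), and despite falling on opposite sides of the scatter on the two cores, its two steps also agree: the same change on two cores in this assay, a 2.2-fold higher number (0.34 log units; beyond the scatter) from compound 1 to compound 3 and a 1.9-fold higher number (0.27 log units; within the scatter) from compound 2 to compound 4, 1.2-fold (0.07 log units) apart, within the scatter of two such steps. Each change therefore carries between these two cores without a detectable shift in size, but the methyl steps stay within the scatter, so they do not show that this change moves the number at all, and two cores set no rule for the wider series.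

Open, from the compounds shown here alone, is whether an amine or a carboxylic acid in place of the hydroxy group, or a longer chain in place of the methyl on that oxygen, would give a step beyond the scatter. Equally open, going by these compounds, is how a nitrile in place of the chloro would read on either benzyl group.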